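Pyridin-2-yl in Place of 2-Methylphenyl: Expected Effect

The source may report more compounds than this note shows. Statements on the series, on what has been measured and on what is new or still open speak of the compounds shown alone.

Compound 2 `Cc1ccccc1N1CCN(C(=S)SCc2ccc3nc(N)nc(N)c3c2)CC1` gives 4230 nM in a functional assay on MCF7 cells (Homo sapiens) for antiproliferative activity, read by MTT assay, with a stated time of 72 h (on this read-out higher numbers stand for weaker inhibition and lower numbers for stronger inhibition), the highest of the two numbers measured. Its nearest neighbour, compound 1 `Nc1nc(N)c2cc(CSC(=S)N3CCN(c4ccccc4)CC3)ccc2n1`, gives 2950 nM in this assay, and the step of a 1.4-fold higher number from compound 1 to compound 2 (0.16 log units; within the scatter) lies within the scatter. Compound 3 `Nc1nc(N)c2cc(CSC(=S)N3CCN(c4ccccn4)CC3)ccc2n1` is not yet measured; it differs from compound 2 by pyridin-2-yl in place of 2-methylphenyl on an amine nitrogen in a ring. Within the data shown here, the only measured step bearing on this, from compound 1 to compound 2, adds the same methyl and was small; no measured pair exchanges 2-methylphenyl for pyridin-2-yl. The step of a 1.3-fold lower number from compound 2 to compound 3 (0.12 log units; within the scatter) is therefore expected to stay within the scatter. Compound 3 is estimated at 3200 nM, ranging from 1200 nM to 8500 nM.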

Compound 3, half-maximal inhibitory concentration: 5110 nM
Compound 3: the middle estimate sits 1.6-fold (0.20 log units) below what was measured, and the stated range covers the measured number.
By their numbers in this assay, from the lowest: compounds 1, 2 and 3 (each within the scatter of the next).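

In this assay, putting a ring nitrogen into the aromatic group on this amine nitrogen leaves the number within the scatter, both for pyridin-2-yl in place of 2-methylphenyl (a 1.2-fold higher number from compound 2 to compound 3 (0.08 log units; within the scatter)) and for pyridin-2-yl in place of phenyl (a 1.7-fold higher number from compound 1 to compound 3 (0.24 log units; within the scatter)). So this position has now taken a hydrogen-bond acceptor in that ring, as well as a methyl, without any step beyond the scatter. Nothing measured here explains why these numbers stay so close. From the compounds shown here alone, whether a non-aromatic group on this nitrogen, such as benzyl or acetyl, would move the number beyond the scatter remains open.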